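A few compounds are considered here, and "the series" means these few. Any claim that something is new, unique, unknown or untested is made for them only; others in the source may bear on it.

Compound 1 `COc1ccc(C2C(O)C(=O)N2c2cc(OC)c(OC)c(OC)c2)cc1` gives 4 nM
Compound 2 `C=CC1C(=O)N(c2cc(OC)c(OC)c(OC)c2)C1c1ccc(SC)cc1` gives 51 nM

Both numbers come from a functional assay on MCF7 cells (Homo sapiens) for inhibition, read by resazurin assay, with a stated time of 72 h (on this read-out lower numbers stand for stronger inhibition and higher numbers for weaker inhibition), and show compound 1 as the lower of the two. Compound 2 stands clearly higher, with a gap beyond the usual scatter of repeat measurements. Compound 3 `COc1ccc(C2C(O)C(=O)N2c2cc(OC)c(OC)c(OC)c2)cc1O` has not been measured yet. It keeps the core of compound 1 but changes 4-methoxyphenyl to 3-hydroxy-4-methoxyphenyl, with hydroxy in place of hydrogen on an aromatic carbon, ortho to a methoxy group (hydroxy in place of hydrogen on an aromatic carbon). Within the data shown here, no two measured compounds differ in just one place, so no direct precedent exists for this change. In this assay the expected step of a 1.3-fold higher number from compound 1 to compound 3 (0.10 log units; within the scatter) stays within the scatter, with no firm direction. In this assay the estimated value for compound 3 is 5 nM (expected range 1.5 nM to 20 nM).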

Compound 3, half-maximal inhibitory concentration: 3 nM
The estimate for compound 3 lay 1.7-fold (0.22 log units) above the measured number; measured number inside the range.
By their numbers in this assay, from the lowest: compounds 3 and 1 (each within the scatter of the next); then compound 2.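

In this assay hydroxy in place of hydrogen on the aromatic carbon ortho to a methoxy group gives a 1.3-fold lower number from compound 1 to compound 3 (0.12 log units; within the scatter) and so leaves compound 1 and compound 3 indistinguishable in this read-out. Among these compounds, this is the first pair here that differs in only one place, and it shows that this position accepts a hydroxy group, with its one hydrogen-bond donor and one hydrogen-bond acceptor, without a loss that can be told from the scatter. No supporting data bear on why the two numbers match.

The compounds shown leave open whether an amine, a chlorine atom or a longer ethoxy chain would be accepted at this same position. They also leave open whether hydroxy would be accepted equally well on compound 2, which carries different groups.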